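The compounds below may be only part of what the source reports. "The series", "measured", "known", "first", "only" and "open" are said of these compounds alone.

Measured compounds:
- compound 1, `COC(=O)C1=C(C)NC(C)=C(C(=O)OC)C1c1ccc(OCC(=O)N2CCCC(C)C2)c(OC)c1`, gives 10000 nM in an assay on cells for inhibition of Voltage-gated L-type calcium channel (Rattus norvegicus), read by fluorescence and calcium flux, with stated times of 30 min and 2 min; on this read-out lower numbers stand for stronger inhibition and higher numbers for weaker inhibition
- compound 2, `COC(=O)C1=C(C)NC(C)=C(C(=O)OC)C1c1ccc(OCC(=O)N2CCCCC2)c(OC)c1`, gives 10000 nM in this assay
- compound 3, `COC(=O)C1=C(C)NC(C)=C(C(=O)OC)C1c1ccc(OCC(=O)N2CCN(C)CC2)c(OC)c1`, gives 9100 nM in this assay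

The three compounds share one core and differ only in the amine joined to the carbonyl carbon of the side chain. Compound 3 has the lowest of the three numbers, yet its steps to both neighbours, a 1.1-fold lower number from compound 1 to compound 3 (0.04 log units; within the scatter) and a 1.1-fold lower number from compound 2 to compound 3 (0.04 log units; within the scatter), lie within the scatter, so no real order among the three can be read from these figures. The step from compound 1 to compound 2, no change at the digits printed from compound 1 to compound 2 (within the scatter), is likewise flat.

Compound 4, `COC(=O)C1=C(C)NC(C)=C(C(=O)OC)C1c1ccc(OCC(=O)n2ccnc2)c(OC)c1`, takes this exchange one step further: 1H-imidazol-1-yl in place of 4-methylpiperazin-1-yl on a carbonyl carbon. The two measured exchanges at this same carbonyl carbon each left the number essentially unchanged, so the expectation for compound 4 in this assay is a 1.1-fold higher number from compound 3 to compound 4 (0.04 log units; within the scatter), a step of no real size in either direction. Compound 4 is therefore estimated at 10000 nM, with a range from 4000 nM to 25000 nM.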

Compound 4, half-maximal inhibitory concentration: 10100 nM
Compound 4: the middle estimate sits 1.0-fold (0.00 log units) below what was measured, within the range that was stated.
By their numbers in this assay, from the lowest: compounds 3, 1, 2 and 4 (each within the scatter of the next).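

In this assay, the change to 1H-imidazol-1-yl on this carbonyl carbon gives steps that all lie within the scatter (a 1.1-fold higher number from compound 3 to compound 4 (0.05 log units; within the scatter); a 1.0-fold higher number from compound 2 to compound 4 (0.00 log units; within the scatter); a 1.0-fold higher number from compound 1 to compound 4 (0.00 log units; within the scatter)). The earlier compounds carried only six-membered non-aromatic rings here, whereas compound 4 has a five-membered aromatic ring, so a change in ring size and ring type together still leaves no readable difference among these four compounds. No measurement is at hand that could explain why they read alike.

Going by these compounds, whether an open-chain amine such as diethylamino, or a morpholine ring, on this carbonyl carbon would give a different number remains open. So does whether a longer chain in place of the ((1H-imidazol-1-yl)carbonyl)methyl group would shift the number.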